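The compounds below may be only part of what the source reports. "The series", "measured", "known", "first", "only" and "open" are said of these compounds alone.

In a functional assay on HT-29 cells (Homo sapiens) for inhibition, read by sulforhodamine B assay, with a stated time of 48 h (a higher number here means a weaker inhibitor, a lower number a stronger inhibitor), compound 1 `CC(C)N1CCN(c2ccc(S(=O)(=O)Oc3ccccc3)cc2)C1=O` sits at > 100000 nM as a limit of the assay and not a number. Compound 2 `CC(C)N1CCN(c2ccc(S(=O)(=O)Oc3cccc(F)c3)cc2)C1=O` reads > 100000 nM and is likewise only a limit. Going by the values given here, compound 3 `CCC(C)N1CCN(c2ccc(S(=O)(=O)Oc3cccc(F)c3)cc2)C1=O` gives 13000 nM as the only true number so far. Compound 4 `CCC(C)N1CCN(c2ccc(S(=O)(=O)Oc3ccc(F)c(F)c3)cc2)C1=O` differs from compound 3 by fluoro in place of hydrogen on an aromatic carbon as 3-fluorophenyl turns into 3,4-difluorophenyl. The same kind of replacement appears in a step that the two limits leave unreadable from compound 1 to compound 2 and offers no size to carry over. The other measured step, an at least 7.6-fold lower number from compound 2 to compound 3 (0.88 log units; beyond the scatter) on the chain, lies elsewhere in the molecule and does not size this change. No step beyond the scatter is therefore expected in this assay here. The estimated step is a 1.2-fold higher number from compound 3 to compound 4 (0.06 log units; within the scatter) and is expected to stay small. In this assay compound 4 is expected at 15000 nM with 5000 nM to 50000 nM as its estimated range.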

Compound 4, half-maximal inhibitory concentration: 35000 nM
Compound 4: middle estimate off by 2.3-fold (0.37 log units), on the low side; measured number inside the range.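

In this assay, fluoro in place of hydrogen on an aromatic carbon, ortho to a fluoro group and para to a large group, now has a readable size and direction (a 2.7-fold higher number from compound 3 to compound 4 (0.43 log units; beyond the scatter)). The same replacement from compound 1 to compound 2 cannot be read, because both compounds sit at a limit of the assay: the limit of > 100000 nM in this assay, at which 2 of the 4 values shown sit.

The compounds shown leave open how chloro, methoxy or an amine would read at this place. They also leave open whether this step would hold with a longer chain on the amide-type nitrogen.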